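Compound 4: 2,6-dimethoxyphenyl on the shared core

A few compounds are considered here, and "the series" means these few. Any claim that something is new, unique, unknown or untested is made for them only; others in the source may bear on it.

Values in a functional assay on HOS-TE85 cells (Homo sapiens) for inhibition, read by CCK-8 assay, with a stated time of 72 h; a higher number here means a weaker inhibitor, a lower number a stronger inhibitor:
compound 1 `COc1ccc(C)cc1N1C(=O)CSC1c1cccc(C(=O)NCCCCc2ccccc2)c1`: 300 nM
compound 2 `COc1ccc(OC)c(N2C(=O)CSC2c2cccc(C(=O)NCCCCc3ccccc3)c2)c1`: > 1000 nM (a limit)
compound 3 `CCN1C(=O)CSC1c1cccc(C(=O)NCCCCc2ccccc2)c1`: > 1000 nM (a limit)

Compound 3 gives no number, only (the limit of > 1000 nM in this assay, at which 2 of the 3 values shown sit), so any step starting from it is anchored to a limit. Compound 4 `COc1cccc(OC)c1N1C(=O)CSC1c1cccc(C(=O)NCCCCc2ccccc2)c1` carries 2,6-dimethoxyphenyl in place of ethyl on an amide-type nitrogen in a ring, and the count of the change reads (2,6-dimethoxyphenyl in place of ethyl on an amide-type nitrogen in a ring).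

For the measured compounds named here, three measured steps bear on this. Ethyl in place of 2-methoxy-5-methylphenyl gave an at least 3.3-fold higher number from compound 1 to compound 3 (0.52 log units; beyond the scatter), which favours an aromatic group at this nitrogen. The aromatic group alone is not enough, however. Methoxy in place of methyl gave an at least 3.3-fold higher number from compound 1 to compound 2 (0.52 log units; beyond the scatter), a change that also produces a dimethoxyphenyl compound. The third step, a step that the two limits leave unreadable from compound 2 to compound 3, adds no size. Compound 4 therefore has one measured analogue on each side, and the closer one in substituent type, compound 2, gives only a limit.

In this assay a modest move toward a lower number is possible, but a result still at the limit is about as likely. The expected step is a number no higher from compound 3 to compound 4 (the limit leaves the size open) as an estimate. For compound 4 the estimated value is 1000 nM, with an expected range from 350 nM to 3000 nM as the estimate.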

Compound 4, half-maximal inhibitory concentration: > 1000 nM
Compound 4: no number, only a limit; the forecaster's own chance of this, stated with the estimate: 60%; the middle value sits exactly at the limit.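

In this assay compound 4 gives > 1000 nM, which is a limit, so a second dimethoxyphenyl compound joins compound 2 at the limit of the assay: the limit of > 1000 nM in this assay, at which 3 of the 4 values shown sit.

Placing 2,6-dimethoxyphenyl in place of 2-methoxy-5-methylphenyl on the amide-type nitrogen gives an at least 3.3-fold higher number from compound 1 to compound 4 (0.52 log units; beyond the scatter), so this second methoxy pattern also fails to keep the result of compound 1. Of the aromatic groups shown at this nitrogen, only 2-methoxy-5-methylphenyl gives a number, with compound 1 at 300 nM, and compound 2 and compound 4 both go against any reading that an aromatic group there is enough.

On these data alone, the steps from compound 3 to compound 4 and from compound 2 to compound 4 cannot be read, as limits stand at both ends, so any order among compound 2, compound 3 and compound 4 stays open. Also open, as far as these compounds go, is which part of the 2-methoxy-5-methylphenyl group carries the result, a question that a plain 2-methoxyphenyl, a 5-chloro-2-methoxyphenyl or a phenyl bearing an amine or a carboxylic acid at this nitrogen would bear on.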